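Methoxy for Chloro on the Amide-Bearing Ring of Compound 1

The source may report more compounds than this note shows. Statements on the series, on what has been measured and on what is new or still open speak of the compounds shown alone.

Compound 1 `CC(=O)Nc1ccc(S(=O)(=O)Nc2cccc(-c3nc(-c4ccc(NC(=O)c5cccnc5)cc4Cl)no3)c2)cc1` is the reference point of this small set. In a functional assay on MDA-MB-231 cells (Homo sapiens) for antiproliferative activity, read by MTT assay, with a stated time of 72 h (on this read-out lower numbers stand for stronger inhibition and higher numbers for weaker inhibition), compound 1 gives 2500 nM, the only number shown. Compound 2 `CC(=O)Nc1ccc(S(=O)(=O)Nc2cccc(-c3nc(-c4ccc(NC(=O)c5cccnc5)cc4Cl)no3)c2)cc1Cl` carries chloro in place of hydrogen on an aromatic carbon, and in this assay compound 2 gives > 10000 nM, which is a limit rather than a number. Compound 3 `CC(=O)Nc1ccc(S(=O)(=O)Nc2cccc(-c3nc(-c4ccc(NC(=O)c5cccnc5)cc4Cl)no3)c2)cc1C` carries methyl in place of hydrogen on the same aromatic carbon, and in this assay compound 3 gives > 10000 nM, again a limit. Hence an at least 4.0-fold higher number from compound 1 to compound 2 (0.60 log units; beyond the scatter) and an at least 4.0-fold higher number from compound 1 to compound 3 (0.60 log units; beyond the scatter), both read only against (the limit of > 10000 nM in this assay, at which 2 of the 3 values shown sit).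

Compound 4 `COc1cc(NC(=O)c2cccnc2)ccc1-c1noc(-c2cccc(NS(=O)(=O)c3ccc(NC(C)=O)cc3)c2)n1` differs from compound 1 by methoxy in place of chloro on an aromatic carbon. Within the data shown here, this ring is not the one varied in compounds 2 and 3, so the measured steps bear on it only loosely: they show that adding a group on an aromatic carbon elsewhere in the shared core weakened inhibition, but no measured pair swaps chloro for methoxy. The expectation is therefore a weakened or roughly unchanged result, with wide uncertainty, a 1.6-fold higher number from compound 1 to compound 4 (0.20 log units; within the scatter). Compound 4 is estimated at 4000 nM, expected to lie between 1500 nM and 10000 nM.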

Compound 4, half-maximal inhibitory concentration: > 10000 nM
Compound 4 gave a limit, no number (the forecaster's own chance of this, stated with the estimate: 30%); at least 2.5-fold (0.39 log units) between middle value and limit.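

In this assay, putting methoxy in place of chloro on the aromatic carbon ortho to a large group and meta to a ((pyridin-3-yl)carbonyl)amino group gives an at least 4.0-fold higher number from compound 1 to compound 4 (0.60 log units; beyond the scatter). Compounds 2 and 3 had shown a loss of inhibition only on the other aromatic ring, and only when a group was added in place of hydrogen, whereas compound 4 shows a loss from exchanging one group for another at a second place in the shared core, so all three changes from compound 1 now point the same way, with none among them going against it. Compound 4 sits at a limit and not at a number, so this step has a lower bound but no measured size: the limit of > 10000 nM in this assay, at which 3 of the 4 values shown sit.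

Steps between compounds at this limit cannot be read, so the set does not rank methoxy against the chloro and methyl changes made elsewhere. From the compounds shown here alone, whether this position tolerates anything other than chloro remains open, for instance fluoro, a hydrogen, an amine or a longer chain such as ethoxy.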